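Trading a Methyl Group for Fluorine on the Benzyl Arm

The source may hold more compounds than are shown below. What is called first, only, known or untested is meant among the compounds shown, and "the series" means these compounds.

Three compounds sharing one core were tested in an assay on isolated protein for inhibition of protein deacetylase HDAC6 (Homo sapiens), read by fluorescence, with a stated time of 1 h, tested at 100 nM; on this read-out higher numbers stand for more inhibition at the one concentration tested (going by the name of the read-out) and lower numbers for less inhibition. Compound 1 `O=C(NO)c1ccc(OCc2nc(C3CCN(Cc4ccccc4)CC3)no2)cc1` gives 66%, and compound 2 `CN(Cc1nc(C2CCN(Cc3ccccc3)CC2)no1)c1ncc(C(=O)NO)cn1` gives 63%. Compound 3 `Cc1cccc(CN2CCC(c3noc(CN(C)c4ncc(C(=O)NO)cn4)n3)CC2)c1` gives 54%, the lowest of the three numbers; its nearest neighbour is compound 2, and the step of a number 9 percentage points lower from compound 2 to compound 3 (within the scatter) is within the usual scatter of repeated measurements. The gap to compound 1, which stands higher, is beyond that scatter.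

Compound 4 `CN(Cc1nc(C2CCN(Cc3ccc(F)cc3)CC2)no1)c1ncc(C(=O)NO)cn1` is not yet measured. It differs from compound 3 in one place: 4-fluorophenyl in place of 3-methylphenyl on a saturated chain carbon bound to an amine nitrogen in a ring. Cut one bond further out, the same difference reads 3-methylbenzyl to 4-fluorobenzyl.

Within the data shown here, only one measured step touches this part of the molecule, the step from compound 2 to compound 3, where adding a methyl group moved the number within the scatter. Among the measured compounds shown here, no measured pair shows what a fluorine on this ring does, so the data give no ground for a large move in either direction. The step of a number 6 percentage points higher from compound 3 to compound 4 (within the scatter) is therefore expected to stay within the scatter. Compound 4 is estimated at 60%, with a range from 45% to 75%.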

Compound 4, a percentage reported as inhibition, at one concentration (the size of the read-out at that concentration, not a potency): 65%
Estimate against measurement, compound 4: 5 percentage points below, and the stated range covers the measured number.
By their numbers in this assay, from the lowest: compounds 3, 2, 4 and 1 (each within the scatter of the next, the first and the last beyond it).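

In this assay, the benzyl arm now gives its first step beyond the scatter, a number 11 percentage points higher from compound 3 to compound 4 (beyond the scatter), so swapping 3-methylphenyl for 4-fluorophenyl at this position can register in the read-out, if only modestly. Set against the ring without a substituent, however, fluoro in place of hydrogen amounts to a number 2 percentage points higher from compound 2 to compound 4 (within the scatter), so the fluorine cannot be told apart from hydrogen here, and the clear separation exists only between the two substituted rings. Nothing available explains why 3-methylbenzyl and 4-fluorobenzyl part in this way, so the difference stands as an observation without a known cause.

This step changes both the group on the ring and its place on the ring, so the compounds shown cannot say how much of the difference belongs to each. On these data alone, it also remains open how this arm would respond to a chlorine, a methoxy group or an amine on the ring, and whether any of these would rise beyond the scatter from the unsubstituted ring of compound 2.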